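Dropping the Nitrooxy Group from the Benzylidene Ring

The source may report more compounds than this note shows. Statements on the series, on what has been measured and on what is new or still open speak of the compounds shown alone.

Two compounds share one core and differ only in the ring that sits on a carbon with a double bond to nitrogen. Compound 1 `COc1ccc(/C=N/NC(=O)Nc2ccc(Oc3ccnc(-c4nncn4CCN(C)C)c3)c(F)c2)c(OC)c1` carries a 2,4-dimethoxyphenyl there; in a functional assay on HT-29 cells (Homo sapiens) for cytotoxicity, read by MTT assay, with a stated time of 72 h (on this read-out higher numbers stand for weaker inhibition and lower numbers for stronger inhibition), compound 1 gives 1780 nM. Compound 2 `CN(C)CCn1cnnc1-c1cc(Oc2ccc(NC(=O)N/N=C/c3ccccc3O[N+](=O)[O-])cc2F)ccn1` carries a 2-(nitrooxy)phenyl instead, and in this assay compound 2 gives 950 nM. The step of a 1.9-fold lower number from compound 1 to compound 2 (0.27 log units; within the scatter) leaves the two numbers within the usual scatter of each other, so neither compound can be called the stronger of the pair. Compound 3 `CN(C)CCn1cnnc1-c1cc(Oc2ccc(NC(=O)N/N=C/c3ccccc3)cc2F)ccn1` has not yet been measured. It differs from compound 2 by hydrogen in place of nitrooxy on an aromatic carbon. For the measured compounds named here, the only measured step that bears on this change, a 1.9-fold lower number from compound 1 to compound 2 (0.27 log units; within the scatter), altered the same ring and stayed within the scatter, so there is no reason to expect a shift in this assay beyond the scatter here either. The estimate for compound 3 is 1200 nM, with a range from 450 nM to 3200 nM, which means an expected step of a 1.3-fold higher number from compound 2 to compound 3 (0.10 log units; within the scatter).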

Compound 3, half-maximal inhibitory concentration: 1120 nM
Compound 3: the middle estimate sits 1.1-fold (0.03 log units) above what was measured, and the stated range covers the measured number.
By their numbers in this assay, from the lowest: compounds 2, 3 and 1 (each within the scatter of the next).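

Taking the nitrooxy group off and leaving only a hydrogen atom on the ring gives a 1.2-fold higher number from compound 2 to compound 3 (0.07 log units; within the scatter) in this assay, so the full removal of this group does not carry the number outside the usual scatter. The plain phenyl of compound 3 also stands close to the 2,4-dimethoxyphenyl ring, with a 1.6-fold lower number from compound 1 to compound 3 (0.20 log units; within the scatter), which means that the three rings measured so far, with nitrooxy, with two methoxy groups or with neither, cannot be told apart on this read-out. Nothing available here offers an explanation for these small differences.

On these data alone, whether an amine or a carboxylic acid on this ring would give a step beyond the scatter remains open. The same question stands for a longer chain at this position.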